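Fluoro for methyl on the amine-bearing ring

This account rests on a few compounds, and the source may have more. Where it says the series, first, only, none or still open, it means among the compounds named here.

Compound 1, `COC(=O)c1c(Nc2ccc(F)cc2)sc(C(=O)c2ccc(OC)cc2)c1C`, in a functional assay, with a stated time of 150 min, tested at 30 ug/mL; on this read-out lower numbers stand for a weaker effect and higher numbers for a stronger effect at the one concentration tested: 23.3%
Compound 2, `COC(=O)c1c(Nc2ccccc2)sc(C(=O)c2ccc(C)cc2)c1C`, in this assay: 9.35%
Compound 3, `COC(=O)c1c(Nc2ccc(C)cc2)sc(C(=O)c2ccc(C)cc2)c1C`, in this assay: "not active" (no number reported), without a number

Three compounds share one core and differ only in the groups on the two outer rings. Compound 1 gives 23.3% and compound 2 gives 9.35%, a gap that lies beyond the usual scatter; these two differ in two places, so the values are simply set side by side. Within the data shown here, compound 3 stands apart: for it the read-out was recorded only as "not active" (no number reported), so no number can be placed against the others, and no size of step from compound 3 to anything measured can be given.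

Compound 4, `COC(=O)c1c(Nc2ccc(F)cc2)sc(C(=O)c2ccc(C)cc2)c1C`, is the next step. The change is fluoro in place of methyl on an aromatic carbon. Among the measured compounds shown here, no measured pair carries this change, so its size is unknown. For the measured compounds named here, compound 1 is the only measured compound bearing the fluoro group and gives 23.3%, while compound 3, bearing methyl at the same place, was reported inactive; a modest rise, perhaps barely beyond the scatter, is therefore expected in this assay, with a real chance that compound 4 is again reported as not active. Compound 4 is estimated at 10%, within 0% to 25%.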

Compound 4, a percentage reported as activity, at one concentration (the size of the read-out at that concentration, not a potency): "not active" (no number reported)
Compound 4: no number reported, and the estimate cannot be compared.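

Compound 3 and compound 4 were both reported as "not active" in this assay, with no number for either, so no step can be read for the change from (4-methylphenyl)amino to (4-fluorophenyl)amino. Nothing available accounts for this result. The compounds shown leave open whether this swap of methyl for fluoro changes the read-out at all.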